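The compounds below may be only part of what the source reports. "The series", "measured", "known", "first", "only" and "open" are said of these compounds alone.

Measured compounds:
Compound 1 `O=C(CCCCC1CCSS1)NCc1cn(CCCOc2ccc3ccc(=O)oc3c2)nn1`, 42.2%
Compound 2 `O=C(CCCCC1CCSS1)NCc1cn(CCCOc2ccc3cc(-c4ccc(Cl)cc4)c(=O)oc3c2)nn1`, 75.6%
Compound 3 `O=C(CCCCC1CCSS1)NCc1cn(CCCCOc2ccc3ccc(=O)oc3c2)nn1`, 69.8%

All three share a core and were tested in a functional assay on PC-12 cells (Rattus norvegicus) for cytotoxicity, read by MTT assay, with stated times of 3 h and 2 h, tested at 20 uM; on this read-out higher numbers stand for a stronger effect at the one concentration tested and lower numbers for a weaker effect. Compound 3 gives 69.8%, which sits within the scatter of compound 2 and clearly beyond compound 1. Compound 4 `O=C(CCCCC1CCSS1)NCc1cn(CCCCOc2ccc3cc(-c4ccc(Br)cc4)c(=O)oc3c2)nn1` differs from compound 3 in one place: 4-bromophenyl in place of hydrogen on an aromatic carbon. Among the compounds with values here, the only measured step of the same kind is the change from compound 1 to compound 2, which brought a number 33.4 percentage points higher from compound 1 to compound 2 (beyond the scatter). Because a number 33.4 percentage points higher from compound 1 to compound 2 (beyond the scatter) was large and a bromine-bearing phenyl enters here in the same way, a clear rise is expected in this assay, tempered by the read-out already being high. Compound 4 is therefore expected at about 85%, between 68% and 100%, an estimated step of a number 15.2 percentage points higher from compound 3 to compound 4 (beyond the scatter).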

Compound 4, a percentage reported as activity, at one concentration (the size of the read-out at that concentration, not a potency): 45%
Estimate against measurement, compound 4: 40 percentage points above; the whole stated range lies above it.
By their numbers in this assay, from the lowest: compounds 1 and 4 (each within the scatter of the next); then compounds 3 and 2 (each within the scatter of the next).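

In this assay, a halogen-bearing phenyl at this aromatic carbon does not always raise the read-out: 4-bromophenyl brought a number 24.8 percentage points lower from compound 3 to compound 4 (beyond the scatter) while 4-chlorophenyl brought a number 33.4 percentage points higher from compound 1 to compound 2 (beyond the scatter). The two changes therefore point in opposite directions, but they differ in both the halogen and the chain of the starting compound, so neither difference can be singled out. Nothing measured here explains the fall.

From the compounds shown here alone, whether 4-chlorophenyl on compound 3 would also lower the number remains open. So does the outcome for an unsubstituted phenyl or a 4-aminophenyl at this position.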